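Urea aryl swap from compound 3 to compound 4

The compounds below may be only part of what the source reports. "The series", "measured", "known", "first", "only" and "open" are said of these compounds alone.

In a functional assay on Shh Light II cells (Mus musculus) for inhibition, read by a luciferase reporter (a lower number here means a stronger inhibitor, a higher number a weaker inhibitor), compound 1 (`N#Cc1ccccc1NC(=O)N1CCC(c2nc(-c3ccc4ccccc4n3)no2)CC1`) gives 190 nM and compound 2 (`COc1ccccc1OC(=O)N1CCC(c2nc(-c3ccc4ccccc4n3)no2)CC1`) gives 250 nM with the gap within the scatter. Compound 3 (`O=C(Nc1cccnc1Cl)N1CCC(c2nc(-c3ccc4ccccc4n3)no2)CC1`) at 1600 nM has the highest number of the three.

Compound 4 (`Cc1ccccc1NC(=O)N1CCC(c2nc(-c3ccc4ccccc4n3)no2)CC1`) differs by 2-methylphenyl in place of 2-chloropyridin-3-yl on an amide-type nitrogen with 2-methylphenyl in place of 2-chloropyridin-3-yl on an amide-type nitrogen.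

The closest guide is an 8.4-fold higher number from compound 1 to compound 3 (0.93 log units; beyond the scatter) with 2-chloropyridin-3-yl in place of 2-cyanophenyl, and a 6.4-fold higher number from compound 2 to compound 3 (0.81 log units; beyond the scatter) points the same way. From the compounds shown here alone, both are modest and beyond the scatter, but 2-methylphenyl itself is untested.

A modest fall is expected, namely a 4.8-fold lower number from compound 3 to compound 4 (0.69 log units; beyond the scatter) in this assay as an estimate. For compound 4 the expected value is 330 nM with an estimated range of 100 nM to 1100 nM for this compound.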

Compound 4, half-maximal inhibitory concentration: 440 nM
Compound 4: the middle estimate sits 1.3-fold (0.12 log units) below what was measured; measured number inside the range.
By their numbers in this assay, from the lowest: compounds 1, 2 and 4 (each within the scatter of the next, the first and the last beyond it); then compound 3.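

In this assay the step of a 3.6-fold lower number from compound 3 to compound 4 (0.56 log units; beyond the scatter) shows that the amide-type nitrogen accepts a carbon-only 2-methylphenyl ring in place of 2-chloropyridin-3-yl with a modest gain. Methyl in place of cyano on the aromatic carbon still costs something, with a 2.3-fold higher number from compound 1 to compound 4 (0.36 log units; beyond the scatter) as the step, while a 1.8-fold higher number from compound 2 to compound 4 (0.25 log units; within the scatter) stays within the scatter. Nothing on hand explains these differences.

The ring nitrogen and the chlorine change together in compound 3, and a 2-chlorophenyl group would separate them. From the compounds shown here alone, an amine or a carboxylic acid on this aromatic ring remains open.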